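A few compounds are considered here, and "the series" means these few. Any claim that something is new, unique, unknown or untested is made for them only; others in the source may bear on it.

In a functional assay on SW-620 cells (Homo sapiens) for cytotoxicity, read by sulforhodamine B assay, with a stated time of 48 h (a higher number here means a weaker inhibitor, a lower number a stronger inhibitor), three compounds built on a shared core have been measured so far. Compound 1 `COc1ccc(C2=NO[C@]3(C2)C(=O)O[C@@H]2[C@H]3CC[C@H](C)[C@]3(O)C=CC(=O)[C@@]23C)cc1` gives 41000 nM and compound 2 `C[C@H]1CC[C@@H]2[C@@H](OC(=O)[C@]23CC(c2ccccc2[N+](=O)[O-])=NO3)[C@]2(C)C(=O)C=C[C@@]12O` gives 40000 nM. Compound 3 `COc1ccc(C2=NO[C@]3(C2)C(=O)O[C@@H]2[C@H]3CC[C@H](C)[C@]3(O)C=CC(=O)[C@@]23C)cc1OC` gives 86000 nM, the highest number of the three and so the weakest inhibitor here.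

Compound 4 `Cc1cccc(C2=NO[C@]3(C2)C(=O)O[C@@H]2[C@H]3CC[C@H](C)[C@]3(O)C=CC(=O)[C@@]23C)c1` keeps the core and differs from compound 3 only in its aromatic group: 3-methylphenyl in place of 3,4-dimethoxyphenyl on a carbon with a double bond to nitrogen. This puts 3-methylphenyl in place of 3,4-dimethoxyphenyl on a carbon with a double bond to nitrogen.

Three measured steps change the group at this place or on its aromatic ring. Adding one methoxy gave a 2.1-fold higher number from compound 1 to compound 3 (0.32 log units; beyond the scatter), and the exchange of 2-nitrophenyl for 3,4-dimethoxyphenyl gave a 2.2-fold higher number from compound 2 to compound 3 (0.33 log units; beyond the scatter). Replacing 4-methoxyphenyl with 2-nitrophenyl gave a 1.0-fold lower number from compound 1 to compound 2 (0.01 log units; within the scatter). All three steps are small, and compound 3 sits at the top of the range, so a modest move back towards compound 1 and compound 2 seems likely. The expected change is a 1.7-fold lower number from compound 3 to compound 4 (0.24 log units; within the scatter). The estimated value for compound 4 is 50000 nM, with an expected range from 25000 nM to 100000 nM.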

Compound 4, half-maximal inhibitory concentration: 15000 nM
The estimate for compound 4 lay 3.3-fold (0.52 log units) above the measured number; measured number outside the range, below it.
By their numbers in this assay, from the lowest: compound 4; then compounds 2 and 1 (each within the scatter of the next); then compound 3.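

In this assay the aromatic group on this carbon proved able to lower the number well beyond the scatter, since the all-carbon 3-methylphenyl in place of 3,4-dimethoxyphenyl gives a 5.7-fold lower number from compound 3 to compound 4 (0.76 log units; beyond the scatter) and is the largest step in the series. The same group also separates from the two compounds that had stood level, with a 2.7-fold lower number from compound 2 to compound 4 (0.43 log units; beyond the scatter) and a 2.7-fold lower number from compound 1 to compound 4 (0.44 log units; beyond the scatter) as its steps, which makes compound 4 the strongest inhibitor of the four. Nothing available explains why this exchange lowers the number.

Compound 4 is the only one shown with a methyl on the aromatic ring, so a single result cannot say how much depends on that methyl. From the compounds shown here alone, whether an unsubstituted phenyl, a longer alkyl chain or an amine on the ring would lower the number further remains open.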